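The source may hold more compounds than are shown below. What is called first, only, known or untested is meant among the compounds shown, and "the series" means these compounds.

Compound 1 `COc1ccc(-c2cc(/C=C/C(=O)c3ccc(N)cc3)[nH]n2)cc1`: 100%
Compound 2 `COc1cc(-c2cc(/C=C/C(=O)c3ccc(N)cc3)[nH]n2)cc(OC)c1OC`: 97%
Compound 3 `COc1cc(-c2cc(/C=C/C(=O)c3ccc(F)c(F)c3)[nH]n2)cc(OC)c1OC`: 90%

These three compounds were measured in a functional assay on RPMI-8226 cells (Homo sapiens) for cytotoxicity, read by sulforhodamine B assay, with a stated time of 48 h, tested at 0.1 uM; on this read-out lower numbers stand for a stronger effect and higher numbers for a weaker effect at the one concentration tested. Among the three numbers, compound 2 stands second highest; its nearest neighbour is compound 1, and its furthest is compound 3, whose number lies a number 7 percentage points lower from compound 2 to compound 3 (within the scatter). All three read-outs sit close together, so this assay draws no distinction between them.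

Compound 4 `COc1ccc(-c2cc(/C=C/C(=O)c3ccc(N)cc3)[nH]n2)cc1OC` has not yet been measured. It differs from compound 2 in one place: hydrogen in place of methoxy on an aromatic carbon. For the measured compounds named here, the one measured step, from compound 2 to compound 3, concerns a different part of the structure and a different kind of exchange, so it bears on compound 4 only in showing how little the read-out moved. Going by the values given here, no measured pair isolates the loss of a methoxy group. Still, compound 1, carrying a single methoxy group, gives 100% and compound 2 gives 97%, so taking away one methoxy group is expected to leave the number essentially where it is. The expected step of no change at the digits printed from compound 2 to compound 4 (within the scatter) stays within the scatter. Compound 4 is therefore estimated at 97%, with a range from 87% to 105%.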

Compound 4, a percentage reported as activity, at one concentration (the size of the read-out at that concentration, not a potency): 96%
For compound 4 the middle estimate is 1 percentage points above the measured one; the measured number falls inside the stated range.
By their numbers in this assay, from the lowest: compounds 3, 4, 2 and 1 (each within the scatter of the next).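

In this assay, for the compounds shown here, hydrogen in place of methoxy on this aromatic carbon gives a number 1 percentage points lower from compound 2 to compound 4 (within the scatter), the first pair to isolate this exchange, since compounds 1 and 2 differ in more than one place. Read from the other side, methoxy in place of hydrogen on the same ring gives a number 4 percentage points lower from compound 1 to compound 4 (within the scatter), so neither single exchange separates the compounds at the one concentration tested. No supporting measurement is available to explain this flat result.

From the compounds shown here alone, whether a hydroxyl group, an amine or a longer chain such as ethoxy on this aromatic carbon would move the number remains open. Also open, going by these compounds, is whether these methoxy exchanges would separate the compounds at other concentrations, where the read-out may not sit so close together.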